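The source may report more compounds than this note shows. Statements on the series, on what has been measured and on what is new or still open speak of the compounds shown alone.

Compound 1 `C[C@@H]1CN(Cc2ccc(-c3ccccc3CN(C)C(=O)CSc3ccccc3)cc2)C[C@H](C)N1` gives 3.16 nM in a functional assay on HEK293 cells for agonist activity at Motilin receptor (Homo sapiens), read by FLIPR; a higher number here means that more compound is needed for the effect, a lower number that less compound is needed. Compound 2 `C[C@@H]1CN(Cc2ccc(-c3ccccc3CN(C)C(=O)CS(=O)(=O)c3ccccc3)cc2)C[C@H](C)N1` gives 10 nM in this assay, the highest of the two numbers shown; the only measured step, a 3.2-fold higher number from compound 1 to compound 2 (0.50 log units; beyond the scatter), ends at it. Compound 3 `Cc1ccc(S(=O)(=O)NCC(=O)N(C)Cc2ccccc2-c2ccc(CN3C[C@@H](C)N[C@@H](C)C3)cc2)cc1` differs from compound 2 by ((4-methylphenyl)sulfonyl)amino in place of phenylsulfonyl on a saturated chain carbon bound to a carbonyl carbon. Among the compounds with values here, no measured step covers a change of this kind; the single step available concerns only phenylsulfanyl against phenylsulfonyl, so it gives little direct guidance. A modest further rise is expected, a 2.0-fold higher number from compound 2 to compound 3 (0.30 log units; within the scatter). Compound 3 is estimated at 20 nM in this assay, within 5 nM to 80 nM.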

Compound 3, half-maximal effective concentration: 20 nM
For compound 3 middle estimate and measured number coincide at the digits printed; measured number inside the range.
By their numbers in this assay, from the lowest: compound 1; then compounds 2 and 3 (each within the scatter of the next).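

At the saturated chain carbon bound to a carbonyl carbon in this assay, ((4-methylphenyl)sulfonyl)amino reads like phenylsulfonyl, with a 2.0-fold higher number from compound 2 to compound 3 (0.30 log units; within the scatter) despite the added hydrogen-bond donor. Against phenylsulfanyl, the same group gives a 6.3-fold higher number from compound 1 to compound 3 (0.80 log units; beyond the scatter) and so extends the gap first seen with phenylsulfonyl to a second sulfonyl-bearing group. Nothing available accounts for either step. The amino link and the 4-methyl group enter together, so their separate contributions stay unresolved. Also open, on these data alone, is how a carboxylic acid or a simple amine at this carbon would read in this assay.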